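Vero cytotoxicity notes: from compound 1 to compound 4

The source may report more compounds than this note shows. Statements on the series, on what has been measured and on what is new or still open speak of the compounds shown alone.

Compound 1 `CCN(CC)c1cc2[nH]c(C3CCCCC3)nc2cc1NC(=O)c1ccc(F)cc1F`: in an ADME assay on Vero cells (Chlorocebus sabaeus) for cytotoxicity, read by resazurin assay, with a stated time of 3 days (a higher number here means a weaker inhibitor, a lower number a stronger inhibitor), compound 1 gives > 100 ug/mL, which is a limit of the assay.
Compound 2 `CN(C)c1cc2[nH]c(C3CCCCC3)nc2cc1NC(=O)c1ccc(F)cc1F`: in this assay compound 2 gives > 100 ug/mL, again a limit.
Compound 3 `O=C(CCc1ccccc1)Nc1cc2nc(C3CCCCC3)[nH]c2cc1N1CCCC1`: in this assay compound 3 gives > 100 ug/mL, again a limit.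

Compound 1 therefore stands only at a limit in this assay, as do both other compounds; all three sit at the limit of > 100 ug/mL in this assay, at which 3 of the 3 values shown sit. Among the measured compounds shown here, the single one-place step, a step that the two limits leave unreadable from compound 1 to compound 2, cannot be read because of the limit of > 100 ug/mL in this assay, at which 3 of the 3 values shown sit.

Compound 4 `C=Cc1cccc(C(=O)Nc2cc3nc(C4CCCCC4)[nH]c3cc2N(CC)CC)c1` differs from compound 1 by 3-vinylphenyl in place of 2,4-difluorophenyl on a carbonyl carbon. For the measured compounds named here, no measured step touches the group on the carbonyl carbon, so nothing here bears on this change. Compound 4 is expected to stay at or near the limit, estimated at 100 ug/mL (range 50 ug/mL to 200 ug/mL). The expected step is a number no higher from compound 1 to compound 4 (the limit leaves the size open), within scatter.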

Compound 4, half-maximal inhibitory concentration: > 100 ug/mL
Compound 4 ended at the assay's limit; the forecaster's own chance of this, stated with the estimate: 75%; the middle value sits exactly at the limit.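

No new step can be read from compound 1 to compound 4, because both stand at a limit: the limit of > 100 ug/mL in this assay, at which 4 of the 4 values shown sit.

The compounds shown leave open whether any change to the groups on the shared core shifts the value in this assay.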